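Moving the trifluoromethyl around a pyridine ring

The source may hold more compounds than are shown below. What is called first, only, known or untested is meant among the compounds shown, and "the series" means these compounds.

Compound 1 `CCN(CCn1ccc(-c2ccc(C(F)(F)F)cn2)n1)C(=O)c1cc(C)ccc1-n1nccn1`: 902 nM
Compound 2 `CCN(CCn1ccc(-c2cc(C(F)(F)F)ccn2)n1)C(=O)c1cc(C)ccc1-n1nccn1`: 66.4 nM

In a functional assay on CHO cells for antagonist activity at Orexin receptor type 2 (Homo sapiens), read by fluorescence and calcium flux, with a stated time of 30 min (a higher number here means a weaker inhibitor, a lower number a stronger inhibitor), compound 2 gives the lowest number of the two, with compound 1 as its nearest neighbour. Compound 3 `CCN(CCn1ccc(-c2cccc(C(F)(F)F)n2)n1)C(=O)c1cc(C)ccc1-n1nccn1` differs from compound 2 by 6-(trifluoromethyl)pyridin-2-yl in place of 4-(trifluoromethyl)pyridin-2-yl on an aromatic carbon. For the measured compounds named here, the only measured step that bears on this, a 14-fold lower number from compound 1 to compound 2 (1.13 log units; beyond the scatter), shows that shifting the trifluoromethyl around the pyridine can move the number a long way, in either direction. Nothing measured points to which way this shift goes, so compound 3 is estimated at 300 nM, with a range of 50 nM to 1800 nM, meaning an expected step of a 4.5-fold higher number from compound 2 to compound 3 (0.65 log units; beyond the scatter).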

Compound 3, antagonist equilibrium constant: 3.92 nM
For compound 3 the middle estimate is 77-fold (1.88 log units) above the measured one, and the stated range ends above it.
By their numbers in this assay, from the lowest: compound 3; then compound 2; then compound 1.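

The trifluoromethyl shift now has a third point, and the number falls again: a 17-fold lower number from compound 2 to compound 3 (1.23 log units; beyond the scatter). Across the set, that is a 230-fold lower number from compound 1 to compound 3 (2.36 log units; beyond the scatter), so the same atoms on the same pyridine cover a wide range, with 6-(trifluoromethyl)pyridin-2-yl giving the lowest number of the three. Nothing available explains why this arrangement gives the lowest number.

Still open, on these data alone, is whether a methyl, a chlorine or a nitrile in place of the trifluoromethyl would keep the number this low. Also open, as far as these compounds go, is what a phenyl ring in place of the pyridine would give.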